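Methyl additions on two related cores

The compounds below may be only part of what the source reports. "The series", "measured", "known", "first", "only" and "open" are said of these compounds alone.

Measured so far:
compound 1, `Cc1cccc(-c2cnc3cccnc3c2)c1`: in a functional assay on CHO cells for antagonist activity at metabotropic glutamate receptor 5 (Rattus norvegicus), read by calcium flux (on this read-out lower numbers stand for stronger inhibition and higher numbers for weaker inhibition), compound 1 gives 15700 nM.
compound 2, `Cc1cc(C)cc(-c2cnc3cccnc3c2)c1`: compound 2 reaches only the limit of > 30000 nM in this assay.
compound 3, `Cc1ccc2cnc(-c3ccccc3)cc2n1`: compound 3 likewise reaches only the limit of > 30000 nM in this assay.

Compound 1 and compound 3 are built from the same atoms joined differently; the difference between the two cores is not broken down here. On the core of compound 1, the change methyl in place of hydrogen on an aromatic carbon gave an at least 1.9-fold higher number from compound 1 to compound 2 (0.28 log units; that floor lies within the scatter), ending at the limit of > 30000 nM in this assay, at which 2 of the 3 values shown sit.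

Compound 4, `Cc1cccc(-c2cc3nc(C)ccc3cn2)c1`, still to be measured, carries the same kind of change on the core of compound 3: methyl in place of hydrogen on an aromatic carbon. The two places are not the same word for word: in compound 2 the entering methyl also sits meta to a methyl group (1 heavy atom), whereas in compound 4 it does not.

The expectation for compound 4 rests on the limit reached by compound 3 and on the step of an at least 1.9-fold higher number from compound 1 to compound 2 (0.28 log units; that floor lies within the scatter). Compound 4 is expected at 60000 nM, most probably again as a limit rather than a number, which means an expected step that the limit leaves unreadable from compound 3 to compound 4.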

Compound 4, half-maximal inhibitory concentration: 676 nM
Estimate against measurement, compound 4: 89-fold (1.95 log units) above; the whole stated range lies above it.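

In this assay, methyl in place of hydrogen on an aromatic carbon gives an at least 44-fold lower number from compound 3 to compound 4 (1.64 log units; beyond the scatter), so the same change does not have the same outcome on the two cores: the same change on two cores in this assay, an at least 1.9-fold higher number (0.28 log units; that floor lies within the scatter) from compound 1 to compound 2 and an at least 44-fold lower number (1.64 log units; beyond the scatter) from compound 3 to compound 4, at least 84-fold (1.92 log units) apart, beyond the scatter of two such steps

The value of compound 3, > 30000 nM, is a limit and not a number, so only a floor is known for the size of this step. These notes rest on a single pair per core, and the entering methyl does not stand in the same surroundings in the two pairs, so the data do not show whether the core itself or that local difference decides the outcome.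

Open, going by these compounds, is whether the lower number on the core of compound 3 holds for a group other than methyl at the same place, such as ethyl or an amine. Also open, on these data alone, is whether this step depends on the methyl group already present on the core of compound 3.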